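The compounds below may be only part of what the source reports. "The series", "measured", "known", "first", "only" and "open" are said of these compounds alone.

Of the compounds shown here, three that share one core have been measured in a functional assay on HCT-116 cells (Homo sapiens) for antiproliferative activity, read by WST assay, with a stated time of 72 h; on this read-out higher numbers stand for an effect only at larger amounts of compound and lower numbers for an effect already at smaller amounts. Compound 1 (`CCCCNCCCCC(=O)Nc1ccc(/C(N)=N/O)cc1`) gives 516000 nM, and compound 3 (`CCCCCCNC(=O)Nc1ccc(/C(N)=N/O)cc1`) gives 195000 nM. Compound 2 (`CCCCCCNCCCC(=O)Nc1ccc(/C(N)=N/O)cc1`) gives 312000 nM, the middle number of the three and within the scatter of the two others. Compound 4 (`CCCCNCCCC(=O)Nc1ccc(/C(N)=N/O)cc1`) has not yet been measured. It differs from compound 2 in one place: hydrogen in place of ethyl on a saturated chain carbon, four bonds along the chain from an amine nitrogen. In words, this is hydrogen in place of ethyl on a saturated chain carbon, four bonds along the chain from an amine nitrogen. Going by the values given here, only one measured step bears on this change, since it too alters the group carried on the saturated chain: a 1.7-fold lower number from compound 1 to compound 2 (0.22 log units; within the scatter). That step stays within the scatter, so no step beyond the scatter is expected in this assay, though a slight drift to a higher number seems likely. The expected step is a 1.3-fold higher number from compound 2 to compound 4 (0.13 log units; within the scatter). For compound 4 the estimated value is 420000 nM, with an expected range from 210000 nM to 800000 nM.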

Compound 4, half-maximal effective concentration: 267000 nM
The estimate for compound 4 lay 1.6-fold (0.20 log units) above the measured number, within the range that was stated.
By their numbers in this assay, from the lowest: compounds 3, 4, 2 and 1 (each within the scatter of the next, the first and the last beyond it).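

Removing the ethyl, on a saturated chain carbon, four bonds along the chain from an amine nitrogen, gives a 1.2-fold lower number from compound 2 to compound 4 (0.07 log units; within the scatter) in this assay, so this change leaves compound 2 and compound 4 indistinguishable. The change of butylamino in place of (butylamino)methyl, on a saturated chain carbon, three bonds along the chain from a carbonyl carbon, gives a 1.9-fold lower number from compound 1 to compound 4 (0.29 log units; within the scatter), so compound 1 and compound 4 cannot be told apart either. Nothing available here explains why these chain changes leave the number inside the scatter.

Still open, as far as these compounds go, is whether a different group on this chain, such as a carboxylic acid, a second amine or a much longer chain, would produce a step beyond the scatter. From the compounds shown here alone, it is also open whether the same picture would hold on cells other than the one line tested here.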